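A few compounds are considered here, and "the series" means these few. Any claim that something is new, unique, unknown or untested is made for them only; others in the source may bear on it.

Of the compounds shown here, three sharing one core have been tested in a functional assay on NCI-H226 cells (Homo sapiens) for inhibition, read by MTT assay, with a stated time of 48 h, tested at 10 uM; a higher number here means more inhibition at the concentration tested (going by the name of the read-out), a lower number less inhibition. Compound 3 `COc1ccc(Nc2cc(NC(=O)Nc3c(Cl)cccc3Cl)ncn2)cc1C` gives 50%, the highest of the three numbers. Compound 1 `Cc1ccc(Nc2cc(NC(=O)Nc3c(Cl)cccc3Cl)ncn2)cc1F` gives 40.7%, and compound 2 `COc1ccc(Br)cc1Nc1cc(NC(=O)Nc2c(Cl)cccc2Cl)ncn1` gives 33%. The step of a number 9.3 percentage points higher from compound 1 to compound 3 (within the scatter) lies within the scatter, whereas a number 17 percentage points higher from compound 2 to compound 3 (beyond the scatter) is a modest change beyond it, and a number 7.7 percentage points lower from compound 1 to compound 2 (within the scatter) stays within the scatter. Compound 4 `CCc1ccc(Nc2cc(NC(=O)Nc3c(Cl)cccc3Cl)ncn2)cc1` differs from compound 3 at the group on a nitrogen on an aromatic ring: 4-ethylphenyl in place of 4-methoxy-3-methylphenyl on a nitrogen on an aromatic ring. All three measured steps exchange that same group, and only one of them went beyond the scatter. A step of a number 8 percentage points lower from compound 3 to compound 4 (within the scatter) is expected, not beyond the scatter. Compound 4 is accordingly estimated at 42%, between 28% and 58%.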

Compound 4, a percentage reported as inhibition, at one concentration (the size of the read-out at that concentration, not a potency): 39.5%
Beside the measured number, compound 4's estimate is 2.5 percentage points above it; the range from low to high includes it.
By their numbers in this assay, from the lowest: compounds 2, 4, 1 and 3 (each within the scatter of the next, the first and the last beyond it).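

Among the compounds shown here, with 4-ethylphenyl, the group on a nitrogen on an aromatic ring carries neither oxygen nor halogen for the first time in this set. a number 10.5 percentage points lower from compound 3 to compound 4 (beyond the scatter) is a modest step, while a number 6.5 percentage points higher from compound 2 to compound 4 (within the scatter) and a number 1.2 percentage points lower from compound 1 to compound 4 (within the scatter) are not separable from the scatter. Compound 3 thus now stands beyond the scatter from two of the other three compounds, and nothing at hand explains the difference. Going by these compounds, whether an amine, a carboxylic acid or a longer chain on this phenyl ring would shift the inhibition beyond the scatter remains open.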